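Shifting a Hydroxyl Along a Ring: Expected Effect on Potency

The source may hold more compounds than are shown below. What is called first, only, known or untested is meant among the compounds shown, and "the series" means these compounds.

Compound 1 `Oc1ccccc1-c1cc(-c2ccc(F)cc2)cc(-c2ccccc2O)n1` gives > 50000 nM in a functional assay on HCT-15 cells (Homo sapiens) for inhibition; a higher number here means a weaker inhibitor, a lower number a stronger inhibitor.
Compound 2 `Oc1cccc(-c2cc(-c3ccccc3F)cc(-c3ccccc3O)n2)c1` gives 8470 nM in this assay.
Compound 3 `Oc1cccc(-c2cc(-c3ccc(F)cc3)cc(-c3ccccc3O)n2)c1` gives > 50000 nM in this assay.

The values of compound 1 and compound 3 are limits of the assay, not numbers (the limit of > 50000 nM in this assay, at which 2 of the 3 values shown sit). Compound 2 alone gives a number. Compound 2 and compound 1 differ in more than one place; that difference is not broken down here. From compound 2 to compound 3, 4-fluorophenyl replaces 2-fluorophenyl, and the step is an at least 5.9-fold higher number from compound 2 to compound 3 (0.77 log units; beyond the scatter).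

Compound 4 `Oc1cccc(-c2cc(-c3ccccc3F)cc(-c3cccc(O)c3)n2)c1` is not yet measured. It differs from compound 2 by 3-hydroxyphenyl in place of 2-hydroxyphenyl on an aromatic carbon. The same kind of change, (3-hydroxyphenyl in place of 2-hydroxyphenyl on an aromatic carbon), gave a step that the two limits leave unreadable from compound 1 to compound 3; the surroundings differ, there meta to a 2-hydroxyphenyl group and a 4-fluorophenyl group, here meta to a 2-fluorophenyl group and a 3-hydroxyphenyl group. Since that earlier step cannot be read, the expected step from compound 2 to compound 4 is a 2.4-fold higher number from compound 2 to compound 4 (0.37 log units; beyond the scatter), resting only on compound 2 and its value 8470 nM. Compound 4 is expected to give 20000 nM, estimated between 6000 nM and 50000 nM.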

Compound 4, half-maximal inhibitory concentration: 5300 nM
The estimate for compound 4 lay 3.8-fold (0.58 log units) above the measured number, outside the stated range (below it).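

In this assay, putting 3-hydroxyphenyl in place of 2-hydroxyphenyl gives a 1.6-fold lower number from compound 2 to compound 4 (0.20 log units; within the scatter), a step within the usual scatter, so this swap shows no readable effect on the core of compound 2. The same swap from compound 1 to compound 3 cannot be read, because both values are limits of the assay, not numbers: the limit of > 50000 nM in this assay, at which 2 of the 4 values shown sit. One readable pair therefore shows how the change behaves with a 2-fluorophenyl group, but it does not show that the result carries over to a core with a 4-fluorophenyl group.

Every compound shown carries hydroxyphenyl groups, so what an amine or a carboxylic acid in place of the hydroxyl would do stays open. Also open, as far as these compounds go, is how compound 4 would compare with its 4-fluorophenyl counterpart.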